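The source may hold more compounds than are shown below. What is called first, only, known or untested is meant among the compounds shown, and "the series" means these compounds.

Three compounds of one shared core have a number, or a limit, in a functional assay on the whole organism with Rattus norvegicus as the target; a higher number here means that more compound is needed for the effect, a lower number that less compound is needed. Compound 1, `Nc1nc2ccc(SC(F)(F)F)cc2s1`, gives 8 mg/kg in this assay. Compound 2, `Nc1nc2cc(OC(F)(F)F)ccc2s1`, reaches only a limit of the assay in this assay, > 10 mg/kg, so no number is known for it; this limit is the one that stands at the limit of > 10 mg/kg in this assay, at which 1 of the 3 values shown sits. Compound 3, `CCCn1c(=N)sc2cc(OC(F)(F)F)ccc21`, gives 4.5 mg/kg in this assay, and this number and that of compound 1 lie within the usual scatter of each other, so nothing can be said of an order between them. Compound 4, `N=c1sc2cc(OC(F)(F)F)ccc2n1CCS(N)(=O)=O`, is not yet measured in this assay. It differs from compound 3 in one place: sulfamoyl in place of methyl on a saturated chain carbon, two bonds along the chain from an aromatic nitrogen. Within the data shown here, no measured pair shows this kind of exchange, so the data give no step to lean on. The expected change from compound 3 to compound 4 in this assay is therefore a step of a 1.3-fold higher number from compound 3 to compound 4 (0.12 log units; within the scatter), which is within the scatter and in no firm direction. On that basis, compound 4 is expected to give about 6 mg/kg in this assay, with a range from 2 mg/kg to 15 mg/kg, and it may also come out only as a limit, as compound 2 did.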

Compound 4, dose for half-maximal effect: 6 mg/kg
The estimate for compound 4 equals the measured number at the digits printed, within the range that was stated.
By their numbers in this assay, from the lowest: compounds 3, 4 and 1 (each within the scatter of the next). At a limit, above all of these: compound 2.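

In this assay, sulfamoyl in place of methyl on a saturated chain carbon, two bonds along the chain from an aromatic nitrogen, gives a step of a 1.3-fold higher number from compound 3 to compound 4 (0.12 log units; within the scatter), so the numbers of the two compounds cannot be told apart. Among these compounds, this is the first step read at this place, since the earlier compounds offered no pair differing in one place, and it shows that a group with more heavy atoms, carrying a hydrogen-bond donor and hydrogen-bond acceptors where methyl carries none, still gives a measured number in this assay rather than a limit. Nothing measured among these compounds offers a reason for this outcome.

Going by these compounds, whether the same holds for other groups at this place, such as an amine, a carboxylic acid or a longer chain ending in sulfamoyl, remains open, as one step cannot show how far this place accepts exchange. On these data alone, it is also open whether sulfamoyl would give a similar step on a chain carried by a core with another substituent in place of the trifluoromethoxy group.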